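This account rests on a few compounds, and the source may have more. Where it says the series, first, only, none or still open, it means among the compounds named here.

Compound 3 `CCC1(Cc2ccccc2)OS(=O)(=O)C=C1OCc1ccccc1Cl` carries 2-chlorophenyl on a saturated chain carbon bound to an oxygen on an unsaturated carbon. In an ADME assay on HEL cells (Homo sapiens) for cytotoxicity, with a stated time of 3 days (a higher number here means that more compound is tolerated, a lower number that less compound is tolerated), compound 3 gives >= 20000 nM, which is a limit of the assay and not a number. Compound 1 `CCC1(Cc2ccccc2)OS(=O)(=O)C=C1OCc1ccc(C)cc1` carries 4-methylphenyl at that saturated chain carbon; in this assay compound 1 gives >= 16000 nM, again a limit. Compound 2 `CCC1(Cc2ccccc2)OS(=O)(=O)C=C1OCC#N` carries cyano at that saturated chain carbon; in this assay compound 2 gives > 400000 nM, also a limit. Compound 3 thus stands on a limit, and the two further values shown are limits as well the limit of > 400000 nM in this assay, at which 1 of the 3 values shown sits, the limit of >= 16000 nM in this assay, at which 1 of the 3 values shown sits (the limit of >= 20000 nM in this assay, at which 1 of the 3 values shown sits).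

Compound 4 `CCC1(Cc2ccccc2)OS(=O)(=O)C=C1OC(=O)c1ccccc1` differs from compound 3 by benzoyl in place of 2-chlorobenzyl on an oxygen on an unsaturated carbon. The measured steps that bear on this change are a step that the two limits leave unreadable from compound 1 to compound 2, a step that the two limits leave unreadable from compound 1 to compound 3 and a step that the two limits leave unreadable from compound 2 to compound 3, none of which can be read in size or direction. No step beyond the scatter is therefore expected, and the expected step of a number no higher from compound 3 to compound 4 (the limit leaves the size open) is set near zero. Compound 4 is estimated at 20000 nM, in a range from 5000 nM to 400000 nM, most likely reported as a limit.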

Compound 4, minimum cytotoxic concentration: > 400000 nM
Compound 4 was reported as a limit; the forecaster's own chance of this, stated with the estimate: 80%; middle value at least 20-fold (1.30 log units) away from the limit.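

All four compounds stand on limits in this assay, so the steps linking compound 4 to compound 1, compound 2 and compound 3 cannot be read in size or direction. The compounds shown leave open whether benzoyl, 2-chlorobenzyl, 4-methylbenzyl and cyanomethyl differ at all in this read-out.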